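Adding a propargyloxy group to compound 2

The compounds below may be only part of what the source reports. "The series", "measured", "known", "first", "only" and "open" are said of these compounds alone.

Compound 1 `C#CCN(c1nc(-c2cccc([N+](=O)[O-])c2)no1)C1CCCCC1` gives 34.2 ug/mL
Compound 2 `C#CCN(c1nc(-c2ccccc2)no1)C1CCCCC1` gives 32.1 ug/mL
Compound 3 `CC(=O)OC[C@H]1O[C@H](OC[C@@H](Cn2cc(CN(c3nc(-c4ccc(Br)cc4)no3)C3CCCCC3)nn2)OC(C)=O)C=C[C@@H]1OC(C)=O` gives 39.1 ug/mL

All three numbers come from an ADME assay on RAW264.7 cells (Mus musculus) for cytotoxicity, read by MTT assay, with a stated time of 48 h (a higher number here means that more compound is tolerated, a lower number that less compound is tolerated), and cannot be told apart. Compound 2, at 32.1 ug/mL, lies within the usual scatter of both compound 1 and compound 3.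

Compound 4 `C#CCOc1ccc(-c2noc(N(CC#C)C3CCCCC3)n2)cc1` keeps the structure of compound 2 but has propargyloxy in place of hydrogen on an aromatic carbon, para to a large group (propargyloxy in place of hydrogen on an aromatic carbon).

Among the measured compounds shown here, one measured step bears on this, because it is also a single change on an aromatic carbon: a 1.1-fold lower number from compound 1 to compound 2 (0.03 log units; within the scatter), with hydrogen in place of nitro. Compound 3 carries bromine on its aromatic ring and differs elsewhere too, yet its value of 39.1 ug/mL also stays within the scatter of compound 2. For the measured compounds named here, none of the measured compounds has a propargyloxy group, so this evidence is thin and the range must stay wide.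

No change beyond the scatter is expected in either direction, and the expected step is small (a 1.1-fold higher number from compound 2 to compound 4 (0.02 log units; within the scatter)). The estimated value for compound 4 is 34 ug/mL (from 20 ug/mL to 58 ug/mL).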

Compound 4, half-maximal cytotoxic concentration: 101 ug/mL
Beside the measured number, compound 4's estimate is 3.0-fold (0.47 log units) below it; measured number outside the range, above it.
By their numbers in this assay, from the lowest: compounds 2, 1 and 3 (each within the scatter of the next); then compound 4.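

In this assay, propargyloxy in place of hydrogen on an aromatic carbon, para to a large group, gives a 3.1-fold higher number from compound 2 to compound 4 (0.50 log units; beyond the scatter). Among the compounds shown here, this shows that a single substitution at this place on the six-membered aromatic ring of carbon only can carry the number beyond the scatter, towards more compound being tolerated, something the one earlier step on an aromatic carbon, a 1.1-fold lower number from compound 1 to compound 2 (0.03 log units; within the scatter), with hydrogen in place of nitro, did not show. No measurement shown here accounts for the rise in compound 4.

The compounds shown leave open whether the rise belongs to the whole propargyloxy group or only to a part of it, such as its oxygen link or its triple bond. A methoxy group, a hydroxyl group or a longer ether chain at the same place on the ring would help separate these possibilities, and would show whether this is a property of propargyloxy alone or of substitution at this place more generally.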